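Pyridyl amide variant in a furan sulfamate series

The source may hold more compounds than are shown below. What is called first, only, known or untested is meant among the compounds shown, and "the series" means these compounds.

Compound 2 `Cc1cccc(F)c1N(C)C(=O)c1ccc(-c2ccc(OS(N)(=O)=O)cc2)o1` carries a 2-fluoro-6-methylphenyl group on the amide nitrogen of the shared core. Among the compounds with values here, in an assay on T47D cells for inhibition of Steryl-sulfatase (Homo sapiens), read by HPLC, with a stated time of 24 h (on this read-out higher numbers stand for weaker inhibition and lower numbers for stronger inhibition), compound 2 gives 150 nM, the higher of the two numbers measured so far. The other measured member, compound 1 `Cc1ccccc1N(C)C(=O)c1ccc(-c2ccc(OS(N)(=O)=O)cc2F)o1`, gives 12 nM in this assay, and the gap between compound 1 and compound 2 lies beyond the scatter, though the two differ in more than one place, so no single change accounts for it.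

Compound 3 `Cc1cccnc1N(C)C(=O)c1ccc(-c2ccc(OS(N)(=O)=O)cc2)o1` has not yet been measured. It differs from compound 2 by 3-methylpyridin-2-yl in place of 2-fluoro-6-methylphenyl on an amide-type nitrogen. Within the data shown here, no measured pair isolates this exchange, so any expectation rests on the change itself and on the number for compound 2.

For compound 3 the step of a 1.1-fold higher number from compound 2 to compound 3 (0.05 log units; within the scatter) is expected to stay within the scatter, with no clear direction. Compound 3 is therefore estimated at 170 nM in this assay, with a range from 60 nM to 500 nM.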

Compound 3, half-maximal inhibitory concentration: 1100 nM
For compound 3 the middle estimate is 6.5-fold (0.81 log units) below the measured one; the whole stated range lies below it.
By their numbers in this assay, from the lowest: compound 1; then compound 2; then compound 3.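

In this assay, the group on the amide-type nitrogen proves sensitive to this exchange: 3-methylpyridin-2-yl in place of 2-fluoro-6-methylphenyl gives a 7.3-fold higher number from compound 2 to compound 3 (0.87 log units; beyond the scatter), with the number moving towards weaker inhibition. Within the data shown here, this is the only step so far that isolates a single place, and it links a ring of carbon only, bearing fluorine, to a loss of inhibition when replaced by a ring with one hetero atom and no fluorine. No measurement bears on the reason for this step.

The exchange alters the ring atoms and the fluorine together, and the compounds shown do not separate these two parts. Also open, going by these compounds, is how a methoxy group or a chlorine atom would behave in place of the fluorine on the phenyl ring of compound 2.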